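From Isopropyl to 4-Bromophenyl on the Aromatic Nitrogen

The source may report more compounds than this note shows. Statements on the series, on what has been measured and on what is new or still open speak of the compounds shown alone.

Compound 1 `COc1cc(-c2nccn2C(C)C)cc(OC)c1OC` is tested in a functional assay on HCT-15 cells (Homo sapiens) for antiproliferative activity, read by MTT assay, with a stated time of 72 h; on this read-out lower numbers stand for stronger inhibition and higher numbers for weaker inhibition. Compound 1 gives only a limit of the assay there, > 100000 nM (the limit of > 100000 nM in this assay, at which 1 of the 2 values shown sits). Compound 2 `COc1cc(-c2nccn2-c2ccc3[nH]ccc3c2)cc(OC)c1OC`, which carries an aromatic ring on the aromatic nitrogen instead of the isopropyl, gives 4600 nM in this assay. Compound 3 `COc1cc(-c2nccn2-c2ccc(Br)cc2)cc(OC)c1OC` differs from compound 1 by 4-bromophenyl in place of isopropyl on an aromatic nitrogen. Among the compounds with values here, no measured step covers this change, so the expectation rests on the two values shown. Compound 3 is expected to reach 6000 nM, between 1000 nM and 60000 nM, because compound 2 gives 4600 nM. The expected step of an at least 16-fold lower number from compound 1 to compound 3 (1.22 log units; beyond the scatter) is thus a large gain in this assay.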

Compound 3, half-maximal inhibitory concentration: 11700 nM
The estimate for compound 3 lay 2.0-fold (0.29 log units) below the measured number; the range from low to high includes it.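

In this assay, 4-bromophenyl in place of isopropyl on the aromatic nitrogen gives an at least 8.5-fold lower number from compound 1 to compound 3 (0.93 log units; beyond the scatter), so a step beyond the scatter at this position does not rest on compound 2 alone. The entering group holds 0 hydrogen-bond donors, so this step needs no donor in that group. The full size of the step stays unknown because compound 1 gives only a limit: the limit of > 100000 nM in this assay, at which 1 of the 3 values shown sits.

The compounds shown leave open whether an unsubstituted phenyl would give a similar step, and so what the bromine contributes. They also leave open how an amine or a carboxylic acid on that ring would read.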